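A few compounds are considered here, and "the series" means these few. Any claim that something is new, unique, unknown or untested is made for them only; others in the source may bear on it.

Working notes on the series

Two members of the series have a number in an assay on HEK293 cells for inhibition of sodium- and chloride-dependent glycine transporter 1 (Homo sapiens), read by scintillation proximity assay; on this read-out lower numbers stand for stronger inhibition and higher numbers for weaker inhibition. Compound 1, `O=C(CN(C(=O)c1ccc(-n2ccnc2)cc1)C1CCCCC1)Nc1cc(F)cc(F)c1`, gives 631 nM in this assay. Compound 2, `O=C(CN(C(=O)c1ccc(-c2ccccn2)cc1)C1CCCCC1)Nc1cc(F)cc(F)c1`, gives 63.1 nM in this assay. For the measured compounds named here, the one step between them, a 10-fold lower number from compound 1 to compound 2 (1.00 log units; beyond the scatter), concerns the group on the aromatic carbon only. Within these two numbers compound 2 stands lowest, with compound 1 as its only neighbour.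

Compound 3, `O=C(CN(CC1CC1)C(=O)c1ccc(-c2ccccn2)cc1)Nc1cc(F)cc(F)c1`, has not yet been measured in this assay. It differs from compound 2 in one place: cyclopropylmethyl in place of cyclohexyl on an amide-type nitrogen. The change sits on the amide-type nitrogen, not on the aromatic carbon, so the measured step from compound 1 to compound 2 tells nothing about it. Going by the values given here, the series holds no other pair that varies this nitrogen substituent. The expectation for compound 3 therefore leans on the value of compound 2, with a wide range to allow for a step in either direction: the estimated step is a 2.4-fold higher number from compound 2 to compound 3 (0.38 log units; beyond the scatter). Compound 3 is expected to give about 150 nM in this assay, within roughly 40 nM to 600 nM.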

Compound 3, half-maximal inhibitory concentration: 200 nM
Compound 3: the middle estimate sits 1.3-fold (0.12 log units) below what was measured; low and high end bracket the measured number.
By their numbers in this assay, from the lowest: compound 2; then compound 3; then compound 1.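

The amide-type nitrogen now has its first measured variation: in this assay there is a 3.2-fold higher number from compound 2 to compound 3 (0.50 log units; beyond the scatter), so the number does respond to the group at this position. Cyclopropylmethyl carries fewer heavy atoms than cyclohexyl and a smaller carbon ring, while the counts of hydrogen-bond donors and acceptors and the net charge stay the same, so the step appears without any difference in those counts, and this single pair cannot separate ring size from heavy-atom count. No measured evidence bears on what lies behind the step.

Going by these compounds, it remains open how the number would move with a cyclopentyl group, a benzyl group or an open chain such as isobutyl on this nitrogen, and so whether the trend follows ring size, group size or something else. Also open, on these data alone, is whether the same exchange of cyclohexyl for cyclopropylmethyl would give a step of similar size with 1H-imidazol-1-yl in place of pyridin-2-yl on the aromatic carbon.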